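The source may hold more compounds than are shown below. What is called first, only, known or untested is meant among the compounds shown, and "the series" means these compounds.

Three compounds have been measured in a functional assay on MCF7 cells (Homo sapiens) for cytotoxicity, read by MTT assay, with a stated time of 24 h, tested at 80 ug/mL; on this read-out higher numbers stand for a stronger effect at the one concentration tested and lower numbers for a weaker effect:

compound 1 `Cn1c(-c2ccc(NC(=O)CSc3nc4ccccc4o3)cc2)nc(-c2ccccc2)c1-c1ccccc1` — compound 1 gives 76.3%
compound 2 `Cn1c(-c2ccc(NC(=O)CSc3nc4cc(Cl)ccc4o3)cc2)nc(-c2ccccc2)c1-c1ccccc1` — compound 2 gives 69.1%
compound 3 `Cc1nnc(SCC(=O)Nc2ccc(-c3nc(-c4ccccc4)c(-c4ccccc4)n3C)cc2)s1` — compound 3 gives 85.2%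

Compound 3 carries the highest of the three numbers, though its distance from compound 1 is within the scatter, a number 8.9 percentage points higher from compound 1 to compound 3 (within the scatter), and only its distance from compound 2 is beyond it, a number 16.1 percentage points higher from compound 2 to compound 3 (beyond the scatter). Compound 4 `CN(C)/C=C/N1CCN(CC(=O)Nc2ccc(-c3nc(-c4ccccc4)c(-c4ccccc4)n3C)cc2)CC1` differs from compound 3 in one place: 4-(2-(dimethylamino)ethenyl)piperazin-1-yl in place of (5-methyl-1,3,4-thiadiazol-2-yl)sulfanyl on a saturated chain carbon bound to a carbonyl carbon. Within the data shown here, none of the measured steps makes a change of this kind. The closest are a number 8.9 percentage points higher from compound 1 to compound 3 (within the scatter) and a number 16.1 percentage points higher from compound 2 to compound 3 (beyond the scatter), which exchange one aromatic ring on the sulfur for another and move the number modestly at most, and a number 7.2 percentage points lower from compound 1 to compound 2 (within the scatter), a chloro added to a ring, which stays within the scatter. The new group is larger and non-aromatic, so those steps give only a weak guide; the expected step, a number 15.2 percentage points lower from compound 3 to compound 4 (beyond the scatter), is a small lowering that may not rise beyond the scatter. Compound 4 is therefore estimated at 70%, with a range from 45% to 90%.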

Compound 4, a percentage reported as activity, at one concentration (the size of the read-out at that concentration, not a potency): 34.7%
Compound 4: middle estimate off by 35.3 percentage points, on the high side; measured number below the stated range.
By their numbers in this assay, from the lowest: compound 4; then compounds 2, 1 and 3 (each within the scatter of the next, the first and the last beyond it).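

In this assay, the saturated chain carbon bound to a carbonyl carbon proves far less tolerant of change than the earlier exchanges of one aromatic ring on the sulfur for another had suggested. With 4-(2-(dimethylamino)ethenyl)piperazin-1-yl in place of the sulfanyl group, there is a number 50.5 percentage points lower from compound 3 to compound 4 (beyond the scatter), a number 34.4 percentage points lower from compound 2 to compound 4 (beyond the scatter) and a number 41.6 percentage points lower from compound 1 to compound 4 (beyond the scatter), so the step is large whichever of the three sulfanyl groups leaves. Nothing available explains this fall.

Since the sulfur, the aromatic ring and the chain on the piperazine all change in one step, the compounds shown leave open which of these differences carries the loss. A morpholine or a 4-methylpiperazin-1-yl group on the same carbon would begin to separate them, and a sulfanyl group bearing a simple pyridine ring would test the aromatic ring alone.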